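A few compounds are considered here, and "the series" means these few. Any claim that something is new, unique, unknown or untested is made for them only; others in the source may bear on it.

Compound 3 `Cc1cc(Nc2cc(-c3ccccc3)[nH]n2)n2nc(SCc3nc4ccccc4[nH]3)nc2n1` gives 1790 nM in a functional assay on MGC-803 cells (Homo sapiens) for inhibition, read by MTT assay, with a stated time of 72 h (on this read-out lower numbers stand for stronger inhibition and higher numbers for weaker inhibition), the lowest of the three numbers measured. Compound 1 `Cc1cc(Nc2cc(-c3ccccc3)[nH]n2)n2nc(SCc3c(Cl)cccc3Cl)nc2n1` gives 5280 nM in this assay, and compound 2 `Cc1cc(Nc2cc(-c3ccccc3)[nH]n2)n2nc(SCc3csc4ccccc34)nc2n1` gives 2280 nM. The step of a 2.9-fold lower number from compound 1 to compound 3 (0.47 log units; beyond the scatter) lies beyond the scatter, whereas a 1.3-fold lower number from compound 2 to compound 3 (0.11 log units; within the scatter) lies within it, so compound 3 and compound 2 are not separated. Compound 4 `Cc1cc(Nc2cc(-c3ccccc3)[nH]n2)n2nc(SCc3cccc4ccccc34)nc2n1` differs from compound 3 in one place: naphthalen-1-yl in place of 1H-benzimidazol-2-yl on a saturated chain carbon bound to a sulfur. Every measured step swaps the group on a saturated chain carbon bound to a sulfur, and the bicyclic groups of compound 2 and compound 3 gave a 1.3-fold lower number from compound 2 to compound 3 (0.11 log units; within the scatter), which suggests little movement. Compound 4 is therefore expected to give 2500 nM in this assay, between 1200 nM and 5200 nM, an estimated step of a 1.4-fold higher number from compound 3 to compound 4 (0.15 log units; within the scatter) that should stay within the scatter.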

Compound 4, half-maximal inhibitory concentration: 3120 nM
Beside the measured number, compound 4's estimate is 1.2-fold (0.10 log units) below it; the range from low to high includes it.
By their numbers in this assay, from the lowest: compounds 3, 2, 4 and 1 (each within the scatter of the next, the first and the last beyond it).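

In this assay naphthalen-1-yl, with no hydrogen-bond donors or acceptors, is not separated from 1H-benzimidazol-2-yl, which has one of each (a 1.7-fold higher number from compound 3 to compound 4 (0.24 log units; within the scatter)), nor from 1-benzothiophen-3-yl (a 1.4-fold higher number from compound 2 to compound 4 (0.14 log units; within the scatter)). On this saturated chain carbon bound to a sulfur, a number in this range therefore does not require that donor and acceptor. Naphthalen-1-yl is also not separated from 2,6-dichlorophenyl (a 1.7-fold lower number from compound 1 to compound 4 (0.23 log units; within the scatter)), unlike the bicyclic groups of compound 2 and compound 3.

Nothing shown explains these steps. As far as these compounds go, whether a carboxylic acid or an amine at this position would stay within this range remains open.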